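Methyl amide to ethyl amide in a benzofuran-type acetamide series

The source may report more compounds than this note shows. Statements on the series, on what has been measured and on what is new or still open speak of the compounds shown alone.

Measured compounds:
compound 1 `CNC(=O)/C=C1/COc2cc(OS(=O)(=O)c3ccc([N+](=O)[O-])cc3)ccc21` gives 13%
compound 2 `CNC(=O)Cc1coc2cc(OS(=O)(=O)c3cccc(Cl)c3)ccc12` gives 4%

In an assay (strain Sprague-Dawley) for inhibition of Amine oxidase [flavin-containing] B (Rattus norvegicus), read by spectrophotometry, with a stated time of 5 min, tested at 10 uM (a higher number here means more inhibition at the concentration tested (going by the name of the read-out), a lower number less inhibition), compound 2 gives 4%, the lower of the two values, while compound 1 gives 13%; the gap between them lies within the scatter, so no order can be claimed. Compound 3 `CCNC(=O)Cc1coc2cc(OS(=O)(=O)c3cccc(Cl)c3)ccc12` has not been measured. It differs from compound 2 by methyl in place of hydrogen on a saturated chain carbon bound to an amide-type nitrogen. Going by the values given here, no step between measured compounds is available, so the expectation rests on compound 2 alone. Compound 3 is expected to show a step of a number 2 percentage points higher from compound 2 to compound 3 (within the scatter), which is not beyond the scatter. Compound 3 is estimated at 6%, within -4% to 18%.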

Compound 3, a percentage reported as inhibition, at one concentration (the size of the read-out at that concentration, not a potency): 0%
Estimate against measurement, compound 3: 6 percentage points above, within the range that was stated.
By their numbers in this assay, from the lowest: compounds 3, 2 and 1 (each within the scatter of the next, the first and the last beyond it).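

In this assay, going by these compounds alone, the change from methylcarbamoyl to ethylcarbamoyl gives a number 4 percentage points lower from compound 2 to compound 3 (within the scatter) and so offers the first reading at this position, one that cannot be told apart from the scatter. On this pair, adding methyl on the saturated chain carbon bound to the amide-type nitrogen leaves no measurable mark on the inhibition. No supporting measurement bears on this result. From the compounds shown here alone, whether a propyl chain, a cyclopropyl ring or a terminal amine at this place would produce a step beyond the scatter remains open. So does whether the same methyl change would read alike on the core of compound 1.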